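Exocyclic alkylidene linkage of the thiazolidinedione ring

The compounds below may be only part of what the source reports. "The series", "measured", "known", "first", "only" and "open" are said of these compounds alone.

Compound 3 `CC(C)C(c1ccc(-c2ccc3cccc(F)c3c2)[nH]c1=O)C1SC(=O)NC1=O` gives 110 nM in a functional assay on CHO cells for antagonist activity at prostaglandin E2 receptor EP3 subtype (Homo sapiens), read by cAMP accumulation, with a stated time of 30 min (on this read-out lower numbers stand for stronger inhibition and higher numbers for weaker inhibition), the highest of the three numbers in hand. Compound 1 `CC(C)C(CC1C(=O)NC(=O)N1C)c1ccc(-c2ccc3cccc(F)c3c2)[nH]c1=O` gives 65 nM, and the step of a 1.7-fold higher number from compound 1 to compound 3 (0.23 log units; within the scatter) lies within the scatter. For the measured compounds named here, compound 2 `CCC(CC)C(/C=C1\OC(=O)NC1=O)c1ccc(-c2ccc3cccc(F)c3c2)[nH]c1=O` gives 23 nM, beyond the scatter from compound 3, but compound 2 differs from compound 3 in two places, so no single step is defined there.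

Compound 4 `CC(C)C(/C=C1\SC(=O)NC1=O)c1ccc(-c2ccc3cccc(F)c3c2)[nH]c1=O` carries a group of 8 heavy atoms (4 carbon, 1 nitrogen, 2 oxygen, 1 sulfur; one five-membered non-aromatic ring with 2 hetero atoms) in place of a group of 7 heavy atoms (3 carbon, 1 nitrogen, 2 oxygen, 1 sulfur; one five-membered non-aromatic ring with 2 hetero atoms), on a saturated chain carbon bound to an aromatic carbon and a saturated chain carbon. Going by the values given here, no measured step isolates this change; the one step in hand, from compound 1 to compound 3, concerns a different exchange. Compound 2, whose ring is joined through a double bond, sits at a clearly lower number than compound 3. A modest move toward lower numbers is therefore expected, a 2.2-fold lower number from compound 3 to compound 4 (0.34 log units; beyond the scatter). Compound 4 is estimated at 50 nM, with a range of 15 nM to 160 nM.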

Compound 4, half-maximal inhibitory concentration: 27 nM
Compound 4: middle estimate off by 1.9-fold (0.27 log units), on the high side; low and high end bracket the measured number.
By their numbers in this assay, from the lowest: compounds 2 and 4 (each within the scatter of the next); then compounds 1 and 3 (each within the scatter of the next).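

In this assay, for the compounds shown here, joining the 2,4-dioxo-1,3-thiazolidin-5-yl ring through a double bond gives the first single change at this position beyond the scatter: a 4.1-fold lower number from compound 3 to compound 4 (0.61 log units; beyond the scatter). The double-bonded group also stands apart from the (3-methyl-2,5-dioxoimidazolidin-4-yl)methyl group, a 2.4-fold lower number from compound 1 to compound 4 (0.38 log units; beyond the scatter), a separation that the saturated linkage of compound 3 did not show. Nothing at hand explains this change.

The compounds shown leave open whether the double bond alone carries this shift, and whether a carboxylic acid in place of the ring would hold the number of compound 4.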